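The source may hold more compounds than are shown below. What is called first, only, known or untested is meant among the compounds shown, and "the series" means these compounds.

Measured so far:
Compound 1 `Cc1nnc(N2CCC(C(=O)N3N=CC[C@H]3c3cc(F)cc(F)c3)CC2)o1` gives 3.6 in a physicochemical assay for lipophilicity, read by HPLC, measured as chromatographic lipophilicity, at pH 7.4; on this read-out lower numbers stand for lower lipophilicity and higher numbers for higher lipophilicity.
Compound 2 `CC(=O)N1CCC(C(=O)N2N=CC[C@H]2c2ccccc2)CC1` gives 2.5 in this assay.

Compound 2 stands lowest of the two numbers in this assay; compound 1 lies higher, and that gap is beyond the scatter. Compound 3 `Cc1nnc(N2CCC(C(=O)N3N=CC[C@H]3c3ccccc3)CC2)o1` has not yet been measured in this assay. It differs from compound 2 by 5-methyl-1,3,4-oxadiazol-2-yl in place of acetyl on an amine nitrogen in a ring. For the measured compounds named here, no step between measured compounds isolates this change, so the expectation rests on compound 1 and compound 2 alone. Compound 3 is expected to rise in this assay by a number 0.70 log units higher from compound 2 to compound 3 (beyond the scatter), beyond the scatter. Compound 3 is therefore estimated at 3.2, within 2.7 to 3.7.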

Compound 3, distribution coefficient: 3.2
Estimate against measurement, compound 3: no gap at the digits printed; measured number inside the range.
By their numbers in this assay, from the lowest: compound 2; then compound 3; then compound 1.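

In this assay, 5-methyl-1,3,4-oxadiazol-2-yl in place of acetyl on the amine nitrogen in a ring is now seen on its own, with the phenyl group held constant, and gives a number 0.70 log units higher from compound 2 to compound 3 (beyond the scatter). Phenyl in place of 3,5-difluorophenyl on a saturated ring carbon can also be read separately, as a number 0.40 log units lower from compound 1 to compound 3 (beyond the scatter), so both changes contribute to the gap between the first two compounds. Nothing given here accounts for either step. Going by these compounds, whether each step would hold with the other group in place remains open, since each was read only once. On these data alone, how a urea or a sulfonamide on that ring nitrogen would read in this assay also remains open.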